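Chain extension on the cyclopropyl carbinol boronate series

This account rests on a few compounds, and the source may have more. Where it says the series, first, only, none or still open, it means among the compounds named here.

Measured compounds:
compound 1 `CCCCC/C(=C\B1OC(C)(C)C(C)(C)O1)C(O)(c1ccccc1)C1CC1`: 10400 nM
compound 2 `CCC/C(=C\B1OC(C)(C)C(C)(C)O1)C1(O)CCCc2ccccc21`: 64900 nM
compound 3 `CCCCCCC(C)(O)/C(=C/B1OC(C)(C)C(C)(C)O1)CCC`: 33900 nM

All three were run in a functional assay on ARH-77 cells (Homo sapiens) for cytotoxicity, read by MTT assay, with a stated time of 72 h; on this read-out higher numbers stand for weaker inhibition and lower numbers for stronger inhibition. Compound 1 gives the lowest number of the three, 10400 nM. Compound 3, at 33900 nM, stands above compound 1 by a gap beyond the usual scatter, and compound 2, at 64900 nM, stands further above it again; both gaps to compound 1 lie beyond the scatter. For the measured compounds named here, no pair of measured compounds differs in a single place, so no measured step is available for direct use.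

Compound 4, `CCCCCCCC/C(=C\B1OC(C)(C)C(C)(C)O1)C(O)(c1ccccc1)C1CC1`, has not yet been measured. It differs from compound 1 in one place: propyl in place of hydrogen on a saturated chain carbon, five bonds along the chain from a double-bonded chain carbon. The core is otherwise unchanged. Nothing in the measured set isolates a change of this kind; compounds 2 and 3 differ from compound 1 in more than one place, so their numbers do not read as a chain step. The expectation is therefore a step from compound 1 to compound 4 of a 1.3-fold lower number from compound 1 to compound 4 (0.11 log units; within the scatter), within the scatter, with no confident direction. Compound 4 is estimated at 8000 nM in this assay, with a range from 3000 nM to 25000 nM.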

Compound 4, half-maximal inhibitory concentration: 6360 nM
Compound 4: the middle estimate sits 1.3-fold (0.10 log units) above what was measured, within the range that was stated.
By their numbers in this assay, from the lowest: compounds 4 and 1 (each within the scatter of the next); then compounds 3 and 2 (each within the scatter of the next).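

In this assay, for the compounds shown here, the only one-place comparison is propyl in place of hydrogen on a saturated chain carbon, five bonds along the chain from a double-bonded chain carbon, and it gives a 1.6-fold lower number from compound 1 to compound 4 (0.21 log units; within the scatter) for this change. The earlier compounds shown here offered no such step, and this one shows that the position accepts the added propyl with the shared core unchanged, without the read-out separating the two compounds, so no gain or loss can be assigned to the extension and the two stand together at the low end of the set. No measurement on hand speaks to why the added propyl leaves the number within the scatter, so the result stays a plain observation on this pair.

On these data alone, a single step gives no trend along the chain, so it remains open whether a longer chain at this position would stay within the scatter or move the number beyond it. Equally open, as far as these compounds go, is how a group of a different kind at this position, such as an amine or a carboxylic acid, would read in this assay on the core of compound 1.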